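The source may hold more compounds than are shown below. What is called first, only, known or untested is meant among the compounds shown, and "the series" means these compounds.

Measured so far:
Compound 1 `COc1nc2ccc(Br)cc2cc1C(c1ccccc1)n1cc(-c2ccc(Br)cc2)nn1` — 13.4%
Compound 2 `COc1nc2ccc(Br)cc2cc1C(c1ccccc1)n1cc(-c2ccccc2F)nn1` — 7.33%
Compound 3 `CCOC(=O)c1cn(C(c2ccccc2)c2cc3cc(Br)ccc3nc2OC)nn1` — 2.01%

In an ADME assay on SK-OV-3 cells (Homo sapiens) for cytotoxicity, read by sulforhodamine B assay, with a stated time of 48 h, tested at 10 uM (a lower number here means less inhibition, a higher number more inhibition at the concentration tested (going by the name of the read-out)), compound 3 stands lowest of the three, with compound 2 nearest and compound 1 furthest, the latter gap beyond the scatter. Compound 4 `COc1nc2ccc(Br)cc2cc1C(c1ccccc1)n1cc(-c2cccc(F)c2)nn1` differs from compound 3 in one place: 3-fluorophenyl in place of ethoxycarbonyl on an aromatic carbon. Within the data shown here, two measured steps bear on it. The step of a number 5.3 percentage points lower from compound 2 to compound 3 (within the scatter) ran in the reverse direction and stayed within the scatter; the step of a number 11.4 percentage points lower from compound 1 to compound 3 (beyond the scatter) was beyond the scatter but modest. Reversing from ethoxycarbonyl back to an aryl group therefore suggests a rise in this assay of roughly the size seen with compound 2, so compound 4 is expected to give 8%, within 0% to 18%. That estimate means a step of a number 6 percentage points higher from compound 3 to compound 4 (within the scatter), expected to be small and possibly within the scatter.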

Compound 4, a percentage reported as inhibition, at one concentration (the size of the read-out at that concentration, not a potency): 12.7%
Compound 4: the middle estimate sits 4.7 percentage points below what was measured; low and high end bracket the measured number.
By their numbers in this assay, from the lowest: compounds 3, 2, 4 and 1 (each within the scatter of the next, the first and the last beyond it).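

In this assay, 3-fluorophenyl on this aromatic carbon of the five-membered ring gives a number 10.7 percentage points higher from compound 3 to compound 4 (beyond the scatter), so a second aryl group, after 4-bromophenyl, stands clear of ethoxycarbonyl, which 2-fluorophenyl in compound 2 did not. The aryl groups themselves are not separated, with a number 5.4 percentage points higher from compound 2 to compound 4 (within the scatter) and a number 0.7 percentage points lower from compound 1 to compound 4 (within the scatter) both within the scatter. Nothing available gives a reason for these steps. The compounds shown leave open whether a carboxylic acid or an amine at this position would match ethoxycarbonyl or the aryl groups, and how unsubstituted phenyl would compare.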